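Chalcone series in the neutrophil assay: a bromofuran variant

A few compounds are considered here, and "the series" means these few. Any claim that something is new, unique, unknown or untested is made for them only; others in the source may bear on it.

The shared core of compound 1 `COc1ccc(OC)c(C(=O)/C=C/c2cccs2)c1` carries a thiophen-2-yl on a double-bonded chain carbon bound to a double-bonded chain carbon. In a functional assay on cells (Neutrophil, Rattus norvegicus) for inhibition (a lower number here means a stronger inhibitor, a higher number a weaker inhibitor), compound 1 gives only a limit, > 30000 nM. Compound 2 `COc1ccc(OC)c(C(=O)/C=C/c2ccc(C)o2)c1` bears a 5-methylfuran-2-yl at the same place. Compound 2 also reaches only a limit in this assay, > 30000 nM. Compound 3 `COc1ccc(OC)c(C(=O)/C=C/c2ccc(C)s2)c1` carries a 5-methylthiophen-2-yl there. For compound 3 the this assay likewise reports only a limit, > 30000 nM. Compound 2 therefore stands at the limit together with the other two, and none of the three has a number. The step that the two limits leave unreadable from compound 1 to compound 2 is unreadable, as are a step that the two limits leave unreadable from compound 1 to compound 3 and a step that the two limits leave unreadable from compound 2 to compound 3, because of the limit of > 30000 nM in this assay, at which 3 of the 3 values shown sit.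

Compound 4 `COc1ccc(OC)c(C(=O)/C=C/c2occc2Br)c1` differs from compound 2 in one place: 3-bromofuran-2-yl in place of 5-methylfuran-2-yl on a double-bonded chain carbon bound to a double-bonded chain carbon. Among the measured compounds shown here, no measured step bears on this change with a readable size, and the three limits give no direction. The expectation is thus that compound 4 remains near the limit in this assay. Compound 4 is estimated at 40000 nM, within a range from 8000 nM to 200000 nM. The expected step that the limit leaves unreadable from compound 2 to compound 4 is accordingly none beyond the scatter.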

Compound 4, half-maximal inhibitory concentration: > 30000 nM
Compound 4: no number, only a limit; the forecaster's own chance of this, stated with the estimate: 80%; the middle value lies beyond the limit too.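

In this assay compound 4 gives > 30000 nM, a limit and not a number, so its steps to compound 1, compound 2 and compound 3 cannot be read: the limit of > 30000 nM in this assay, at which 4 of the 4 values shown sit.

The compounds shown leave open how the thiophen-2-yl, 5-methylfuran-2-yl, 5-methylthiophen-2-yl and 3-bromofuran-2-yl groups rank in this assay, and whether any group at this place gives a measurable value.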